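Aryl exchange on the shared core, compound 3 to compound 4

The source may report more compounds than this note shows. Statements on the series, on what has been measured and on what is new or still open speak of the compounds shown alone.

Compound 3 `Cc1nc2c3ccccc3ccc2c2nc3c(ccc4ccccc43)c(-c3cc([N+](=O)[O-])ccc3N)c12` gives 43.3 ug/mL in a functional assay, read by spectrophotometry, with a stated time of 15 min (on this read-out higher numbers stand for weaker inhibition and lower numbers for stronger inhibition), the lowest of the three numbers, though both other compounds sit within the scatter of it: compound 1 `Cc1nc2c3ccccc3ccc2c2nc3c(ccc4ccccc43)c(-c3cccc([N+](=O)[O-])c3)c12` gives 54.2 ug/mL and compound 2 `Cc1nc2c3ccccc3ccc2c2nc3c(ccc4ccccc43)c(-c3cccc4ccccc34)c12` gives 64.3 ug/mL. Compound 4 `Cc1nc2c3ccccc3ccc2c2nc3c(ccc4ccccc43)c(-c3ccccc3S)c12` is not yet measured; the change from compound 3 is 2-sulfanylphenyl in place of 2-amino-5-nitrophenyl on an aromatic carbon. Two measured steps exchange the whole aryl group on the same carbon of the core: a 1.2-fold higher number from compound 1 to compound 2 (0.07 log units; within the scatter) and a 1.5-fold lower number from compound 2 to compound 3 (0.17 log units; within the scatter). The third, a 1.3-fold lower number from compound 1 to compound 3 (0.10 log units; within the scatter), adds only an amino group. All three stay within the scatter, so no step beyond the scatter is expected for compound 4 in this assay. Compound 4 is therefore estimated at 50 ug/mL, with a range of 25 ug/mL to 100 ug/mL. The expected step is a 1.2-fold higher number from compound 3 to compound 4 (0.06 log units; within the scatter).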

Compound 4, half-maximal inhibitory concentration: 49.6 ug/mL
Beside the measured number, compound 4's estimate is 1.0-fold (0.00 log units) above it; the measured number falls inside the stated range.
By their numbers in this assay, from the lowest: compounds 3, 4, 1 and 2 (each within the scatter of the next).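

In this assay, among the compounds shown here, the carbon opposite the ring nitrogen accepts 2-sulfanylphenyl, the only sulfur-bearing group in the set, with no step beyond the scatter: a 1.1-fold higher number from compound 3 to compound 4 (0.06 log units; within the scatter) and a 1.3-fold lower number from compound 2 to compound 4 (0.11 log units; within the scatter) and a 1.1-fold lower number from compound 1 to compound 4 (0.04 log units; within the scatter) all stay within it. Compound 4 carries neither nitro nor amino, so among these four compounds neither group is required to hold the number in this band. No supporting data on the origin of this flat result are available.

On these data alone, whether any group at this carbon moves the number beyond the scatter remains open. A carboxylic acid, a morpholine or a simple methyl there would test this.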